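Compound 2 to compound 4: methyl in place of fluoro

The source may report more compounds than this note shows. Statements on the series, on what has been measured and on what is new or still open speak of the compounds shown alone.

Compound 2 (`Cc1ccc2[nH]c(-c3c(-c4ccc(F)cc4)nc4sc(C)nn34)nc2c1`) gives 6600 nM in a functional assay on ME-180 cells (Homo sapiens) for antiproliferative activity, read by MTT assay; on this read-out lower numbers stand for stronger inhibition and higher numbers for weaker inhibition. Compound 1 (`Cc1nn2c(-c3nc4cc(C(F)(F)F)ccc4[nH]3)c(-c3ccc(F)cc3)nc2s1`) gives 5800 nM, and a 1.1-fold higher number from compound 1 to compound 2 (0.06 log units; within the scatter) places these two together at the low end of the three numbers. Compound 3 (`Cc1nn2c(-c3nc4ccccc4[nH]3)c(-c3ccc(F)cc3)nc2s1`) gives 18100 nM, and a 2.7-fold higher number from compound 2 to compound 3 (0.44 log units; beyond the scatter) sets it apart from compound 2.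

Compound 4 (`Cc1ccc(-c2nc3sc(C)nn3c2-c2nc3cc(C)ccc3[nH]2)cc1`) carries a single change from compound 2: methyl in place of fluoro on an aromatic carbon. This is methyl in place of fluoro on an aromatic carbon, or 4-fluorophenyl to 4-methylphenyl. Among the compounds with values here, no measured step touches that place, since compounds 1, 2 and 3 all keep the 4-fluorophenyl group, so the evidence is only indirect. All three measured steps fall at a different aromatic carbon. Within the data shown here, there, a 3.1-fold higher number from compound 1 to compound 3 (0.49 log units; beyond the scatter) and a 2.7-fold higher number from compound 2 to compound 3 (0.44 log units; beyond the scatter) are modest, while the one exchange of one substituent for another, a 1.1-fold higher number from compound 1 to compound 2 (0.06 log units; within the scatter), stays within the scatter. On that basis, no step beyond the scatter is expected in this assay, though a modest step in either direction cannot be excluded. The expected step is a 1.1-fold lower number from compound 2 to compound 4 (0.04 log units; within the scatter). Compound 4 is estimated at 6000 nM, with an expected range of 2300 nM to 16000 nM.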

Compound 4, half-maximal inhibitory concentration: 4500 nM
Beside the measured number, compound 4's estimate is 1.3-fold (0.12 log units) above it; the measured number falls inside the stated range.
By their numbers in this assay, from the lowest: compounds 4, 1 and 2 (each within the scatter of the next); then compound 3.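

Working from this assay as the read-out, the 4-fluorophenyl to 4-methylphenyl exchange gives a 1.5-fold lower number from compound 2 to compound 4 (0.17 log units; within the scatter) and is the first measured step at this position. All earlier steps fell at a different aromatic carbon, whereas this one shows that, with the rest of compound 2 held constant, methyl can stand in place of fluoro para to a large group without a change beyond the scatter. No measured property is available to explain this small step, so the data give no account of it.

The compounds shown compare only two substituents here, fluoro and methyl, each of a single heavy atom, so it remains open how hydrogen, a methoxy group, an amine, a carboxylic acid or a longer alkyl chain would behave in this place. Within the data shown here, the exchange is also seen only with the methyl group of compound 2 at the other varied aromatic carbon, so whether it reads the same alongside the trifluoromethyl group of compound 1 or the hydrogen of compound 3 remains open.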